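This account rests on a few compounds, and the source may have more. Where it says the series, first, only, none or still open, it means among the compounds named here.

For the measured compounds named here, in a functional assay on HeLa cells (Homo sapiens) for inhibition, read by cell counting, with a stated time of 4 days (on this read-out higher numbers stand for weaker inhibition and lower numbers for stronger inhibition), compound 2 `C=C(Br)C(=O)Nc1cccc(-c2cn3nc(-c4ccc(OC)c(OC)c4)sc3n2)c1` gives 610 nM, the lowest of the two numbers so far; compound 1 `C=C(Br)C(=O)Nc1cccc(-c2cn3nc(-c4ccc(OCC)cc4)sc3n2)c1` gives 1100 nM, and a 1.8-fold lower number from compound 1 to compound 2 (0.26 log units; within the scatter). Compound 3 `C=C(Br)C(=O)Nc1cccc(-c2cn3nc(-c4cccs4)sc3n2)c1` is not yet measured; the change is thiophen-2-yl in place of 3,4-dimethoxyphenyl on an aromatic carbon, an aryl swap on the same aromatic carbon as that earlier step. Going by the values given here, only the step from compound 1 to compound 2 bears on it, and it stayed within the scatter, so no step beyond the scatter is expected in this assay in either direction, the estimated step being a 1.5-fold higher number from compound 2 to compound 3 (0.17 log units; within the scatter). Compound 3 is therefore expected to give about 900 nM, in the range 300 nM to 2700 nM.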

Compound 3, half-maximal inhibitory concentration: 670 nM
Beside the measured number, compound 3's estimate is 1.3-fold (0.13 log units) above it, within the range that was stated.
By their numbers in this assay, from the lowest: compounds 2, 3 and 1 (each within the scatter of the next).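

In this assay thiophen-2-yl (5 heavy atoms) on this aromatic carbon gives a 1.1-fold higher number from compound 2 to compound 3 (0.04 log units; within the scatter) and a 1.6-fold lower number from compound 1 to compound 3 (0.22 log units; within the scatter) so a five-membered sulfur-containing ring and the larger oxygen-substituted phenyl groups (3,4-dimethoxyphenyl has 10 heavy atoms) all stay within the scatter here. Across these three compounds, neither the ring size nor the heavy-atom count of this aryl group separates the numbers. No measured information bears on why these groups read alike. Still open, as far as these compounds go, is whether a piperazine, a carboxylic acid or a longer alkyl chain on this carbon would give a step beyond the scatter.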